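This account rests on a few compounds, and the source may have more. Where it says the series, first, only, none or still open, it means among the compounds named here.

Three measured compounds share one core and differ in a single group on it. In an ADME assay on Raji cells (Homo sapiens) for cytotoxicity, read by CellTiter-Glo and resazurin assay, with a stated time of 72 h (on this read-out lower numbers stand for an effect already at smaller amounts and higher numbers for an effect only at larger amounts of compound), compound 1 `CCOC(=O)CCCCCOc1cccc(CN(C(=O)c2ccc(-c3ccncc3)cc2)C(C)C)c1` reaches only a limit of the assay, > 26000 nM. Compound 2 `CCOC(=O)CCCCCOc1cccc(CN(C(=O)c2ccc(-c3cnc(OC)nc3OC)cc2)C(C)C)c1` likewise gives only a limit in this assay, > 26000 nM. Compound 3 `CCOC(=O)CCCCCOc1cccc(CN(C(=O)c2ccc(-c3cccc([N+](=O)[O-])c3)cc2)C(C)C)c1` also stops at a limit in this assay, > 26000 nM. Compound 3 therefore stands where every measured compound stands, at the limit of > 26000 nM in this assay, at which 3 of the 3 values shown sit, and no readable number separates it from the others. The steps a step that the two limits leave unreadable from compound 1 to compound 2, a step that the two limits leave unreadable from compound 1 to compound 3 and a step that the two limits leave unreadable from compound 2 to compound 3 are all unreadable because of the limit of > 26000 nM in this assay, at which 3 of the 3 values shown sit. Compound 4 `CCOC(=O)CCCCCOc1cccc(CN(C(=O)c2ccc(Br)cc2)C(C)C)c1` is not yet measured; it differs from compound 3 by bromo in place of 3-nitrophenyl on an aromatic carbon. The three measured steps that bear on this change carry no readable size, so neither a direction nor a magnitude can be drawn from them, and the expected step is a step that the limit leaves unreadable from compound 3 to compound 4, nothing beyond the scatter. Compound 4 is estimated in this assay at 40000 nM, with a range from 20000 nM to 100000 nM, most probably again only a limit.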

Compound 4, half-maximal effective concentration: > 26000 nM
Compound 4 gave a limit, no number; the forecaster's own chance of this, stated with the estimate: 85%; the middle value is on the limit's open side.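

The steps linking compound 4 with compound 1, compound 2 and compound 3 cannot be read, because all four compounds give only a limit and no number: the limit of > 26000 nM in this assay, at which 4 of the 4 values shown sit.

The compounds shown leave open whether bromo, pyridin-4-yl, 3-nitrophenyl and 2,4-dimethoxypyrimidin-5-yl differ at all in this assay, and in which direction.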